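The source may hold more compounds than are shown below. What is called first, only, known or untested is meant among the compounds shown, and "the series" means these compounds.

The compounds here share one core and are compared in an ADME assay on L02 cells (Homo sapiens) for cytotoxicity, read by MTT assay, with a stated time of 24 h; a lower number here means a stronger inhibitor, a higher number a weaker inhibitor. In this test compound 1 `O=C1/C(=C/c2cccnc2)CNC/C1=C\c1ccccc1F` gives 15900 nM, and compound 3 `O=C1/C(=C/c2ccncc2)CNC/C1=C\c1ccccc1F` gives 14700 nM. These two values sit level, since exchanging pyridin-3-yl for pyridin-4-yl amounts to a 1.1-fold lower number from compound 1 to compound 3 (0.03 log units; within the scatter). Compound 2 `O=C1/C(=C/c2cccnc2)CN(S(=O)(=O)c2ccc(Cl)cc2)C/C1=C\c1ccccc1F` gives > 20000 nM, which is a limit of the assay and not a number. Compound 3 therefore stands alongside compound 1, and only these two carry actual numbers.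

Compound 4 `O=C1/C(=C/c2ccncc2)CN(S(=O)(=O)c2ccc(Br)cc2)C/C1=C\c1ccccc1F` has not yet been measured. It differs from compound 3 by (4-bromophenyl)sulfonyl in place of hydrogen on an amine nitrogen in a ring, with (4-bromophenyl)sulfonyl in place of hydrogen on an amine nitrogen in a ring. The closest guide is an at least 1.2-fold higher number from compound 1 to compound 2 (0.09 log units; that floor lies within the scatter), where (4-chlorophenyl)sulfonyl enters at the same place. As far as these compounds go, that figure is only a floor, so the true size of the step remains open. The change from chlorine to bromine has not been tested here. The pyridine exchange made little difference in a 1.1-fold lower number from compound 1 to compound 3 (0.03 log units; within the scatter), so a similar step can be expected when starting from compound 3.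

The expected step is a 1.6-fold higher number from compound 3 to compound 4 (0.21 log units; within the scatter). For compound 4 the estimate is 24000 nM, with an expected range from 13000 nM to 60000 nM.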

Compound 4, half-maximal inhibitory concentration: 19400 nM
Estimate against measurement, compound 4: 1.2-fold (0.09 log units) above; measured number inside the range.
By their numbers in this assay, from the lowest: compounds 3, 1 and 4 (each within the scatter of the next). At a limit, above all of these: compound 2.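

Among these compounds, compound 4 gives the first actual number for an arylsulfonyl group on the amine nitrogen in the ring. In this assay, placing (4-bromophenyl)sulfonyl there in place of hydrogen gives a 1.3-fold higher number from compound 3 to compound 4 (0.12 log units; within the scatter), so this group of 10 heavy atoms leaves compound 4 level with compound 3 in this test. Compound 2 gives > 20000 nM, which is a limit of the assay and not a number.

As far as these compounds go, compound 2 and compound 4 differ in two places, the halogen on the benzene ring and the pyridine group, so neither exchange can be read alone, and the step to compound 2 cannot be read in full: the limit of > 20000 nM in this assay, at which 1 of the 4 values shown sits. It also remains open how the number would respond to other groups on the same nitrogen, such as a methylsulfonyl, an acetyl or a benzyl group, or to an amine or a carboxylic acid carried on the benzene ring of the sulfonyl group.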